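This account rests on a few compounds, and the source may have more. Where it says the series, first, only, none or still open, it means among the compounds named here.

Within the data shown here, compound 2 `Cc1ccc(CNC(=O)c2nc(-c3ccc(F)cc3)n(CC[C@@H](O)C[C@@H](O)CC(=O)O)c2C2CC2)cc1` stands second highest of the three numbers measured so far: in an assay on microsomes from liver for inhibition of 3-hydroxy-3-methylglutaryl-coenzyme A reductase (Rattus norvegicus), read by scintillation counting, with stated times of 0.5 h and 0.75 h (on this read-out lower numbers stand for stronger inhibition and higher numbers for weaker inhibition), compound 2 gives 1.7 nM. Its nearest neighbour is compound 3 `COc1cccc(CNC(=O)c2nc(-c3ccc(F)cc3)n(CC[C@@H](O)C[C@@H](O)CC(=O)O)c2C2CC2)c1`, which in this assay gives 1.2 nM, and the step of a 1.4-fold lower number from compound 2 to compound 3 (0.15 log units; within the scatter) lies within the scatter. Compound 1 `Cc1ccccc1CNC(=O)c1nc(-c2ccc(F)cc2)n(CC[C@@H](O)C[C@@H](O)CC(=O)O)c1C1CC1` gives 4.9 nM in this assay; the steps of a 2.9-fold lower number from compound 1 to compound 2 (0.46 log units; beyond the scatter) and a 4.1-fold lower number from compound 1 to compound 3 (0.61 log units; beyond the scatter) both lie beyond the scatter. Compound 4 `COc1ccccc1CNC(=O)c1nc(-c2ccc(F)cc2)n(CC[C@@H](O)C[C@@H](O)CC(=O)O)c1C1CC1` differs from compound 2 by 2-methoxyphenyl in place of 4-methylphenyl on a saturated chain carbon bound to an amide-type nitrogen. The steps bearing on this change are those that exchanged the 2-methylphenyl of compound 1, since compound 4 carries a 2-methoxyphenyl where compound 1 carried a 2-methylphenyl; both of those steps were modest and ran toward lower numbers when the 2-methylphenyl left. It is therefore expected that the number moves back toward that of compound 1 by a modest step, a 2.4-fold higher number from compound 2 to compound 4 (0.37 log units; beyond the scatter). Compound 4 is estimated to give 4 nM in this assay, within a range of 1.5 nM to 10 nM.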

Compound 4, half-maximal inhibitory concentration: 7 nM
The estimate for compound 4 lay 1.8-fold (0.24 log units) below the measured number; low and high end bracket the measured number.
By their numbers in this assay, from the lowest: compounds 3 and 2 (each within the scatter of the next); then compounds 1 and 4 (each within the scatter of the next).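

In this assay, a 1.4-fold higher number from compound 1 to compound 4 (0.15 log units; within the scatter) shows that methoxy in place of methyl on the aromatic carbon makes no difference that can be read beyond the scatter. Among these compounds, the step of a 5.8-fold higher number from compound 3 to compound 4 (0.77 log units; beyond the scatter) is the first to keep the methoxy group and change only its place on the phenyl ring, and that alone is enough to produce a modest loss, of much the same kind as a 4.1-fold higher number from compound 2 to compound 4 (0.61 log units; beyond the scatter). Across these four compounds, then, 2-methylphenyl and 2-methoxyphenyl both stand apart from 4-methylphenyl and 3-methoxyphenyl, with no compound going against this, but nothing available here accounts for that difference.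

The compounds shown leave open how 4-methoxyphenyl or 3-methylphenyl would read in this assay. They also leave open whether a 2-chlorophenyl group would fall with compound 1 and compound 4.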